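This account rests on a few compounds, and the source may have more. Where it says the series, first, only, none or still open, it means among the compounds named here.

Measured compounds:
compound 1, `CCOC(=O)Cn1ncc2c(Nc3ccc(NC(=O)CCl)cc3)ncnc21`: 3.51 ug/mL
compound 2, `CCOC(=O)Cn1ncc2c(Nc3ccc(NS(=O)(=O)c4ccccc4)cc3)ncnc21`: > 100 ug/mL

In a functional assay on cells (Homo sapiens) for inhibition, read by MTT assay, with a stated time of 72 h (on this read-out higher numbers stand for weaker inhibition and lower numbers for stronger inhibition), compound 1 gives 3.51 ug/mL. Compound 2 stands only at a limit of the assay, not a number, in this assay: > 100 ug/mL (the limit of > 100 ug/mL in this assay, at which 1 of the 2 values shown sits). Within the data shown here, the single measured step is an at least 28-fold higher number from compound 1 to compound 2 (1.45 log units; beyond the scatter). Compound 3, `CCOC(=O)Cn1ncc2c(Nc3ccc(NC(=O)c4ccccc4)cc3)ncnc21`, differs from compound 2 by benzoyl in place of phenylsulfonyl on a nitrogen on an aromatic ring. Among the measured compounds shown here, no measured step separates an amide from a sulfonamide with the same aryl group, so the step from compound 1 to compound 2 bears on this only indirectly. The expected step of an at least 1.2-fold lower number from compound 2 to compound 3 (0.09 log units; that floor lies within the scatter) is none beyond the scatter. Compound 3 is estimated at 80 ug/mL, range 20 ug/mL to 200 ug/mL.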

Compound 3, half-maximal inhibitory concentration: > 100 ug/mL
Compound 3 ended at the assay's limit; the forecaster's own chance of this, stated with the estimate: 55%; middle value at least 1.2-fold (0.09 log units) from the limit.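

In this assay, compound 3 keeps the carbonyl on the nitrogen and changes only the group on it, phenyl in place of chloromethyl, and the result is an at least 28-fold higher number from compound 1 to compound 3 (1.45 log units; beyond the scatter). The carbonyl linkage alone therefore does not preserve the read-out of compound 1, and the loss is not confined to the sulfonamide of compound 2. The step between compound 2 and compound 3 cannot be read, as both values are limits of the assay and not numbers: the limit of > 100 ug/mL in this assay, at which 2 of the 3 values shown sit.

Open, from the compounds shown here alone, is whether a methyl or a bromomethyl on the carbonyl carbon would retain the read-out of compound 1. Also open, going by these compounds, is how far compound 2 and compound 3 lie beyond the limit.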